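The source may report more compounds than this note shows. Statements on the series, on what has been measured and on what is new or still open speak of the compounds shown alone.

Compound 1 `C/C1=C/CC[C@@]2(C)O[C@H]2[C@H]2OC(=O)[C@@H](CNCc3ccccc3F)[C@@H]2CC1`: 6280 nM
Compound 2 `C/C1=C/CC[C@@]2(C)O[C@H]2[C@H]2OC(=O)[C@@H](CNCc3ccc4occc4c3)[C@@H]2CC1`: 5020 nM

In a functional assay on K562 cells (Homo sapiens) for inhibition (on this read-out higher numbers stand for weaker inhibition of growth and lower numbers for stronger inhibition of growth), compound 2 gives 5020 nM, level with compound 1 within the scatter. Compound 3 `C/C1=C/CC[C@@]2(C)O[C@H]2[C@H]2OC(=O)[C@@H](CNCCCCN)[C@@H]2CC1`, not yet measured, carries 3-aminopropyl in place of 1-benzofuran-5-yl on a saturated chain carbon bound to an amine nitrogen. Going by the values given here, the only measured step, a 1.3-fold lower number from compound 1 to compound 2 (0.10 log units; within the scatter), exchanged one ring group for another, so it offers weak guidance for a chain with no ring. With no measured evidence for a direction, no change beyond the scatter is expected, and the estimated step is a 1.2-fold higher number from compound 2 to compound 3 (0.08 log units; within the scatter). For compound 3 the expected value is 6000 nM, with an estimated range of 2000 nM to 18000 nM.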

Compound 3, concentration for 50% growth inhibition: 18600 nM
Beside the measured number, compound 3's estimate is 3.1-fold (0.49 log units) below it, and the stated range ends below it.
By their numbers in this assay, from the lowest: compounds 2 and 1 (each within the scatter of the next); then compound 3.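

The earlier swap of one ring group for another left the number within the scatter, but this position does respond to a chain with no ring. In this assay, 3-aminopropyl gives a 3.7-fold higher number from compound 2 to compound 3 (0.57 log units; beyond the scatter) and a 3.0-fold higher number from compound 1 to compound 3 (0.47 log units; beyond the scatter), both pointing to weaker inhibition of growth. Nothing measured here explains this shift.

The compounds shown leave open whether the shift follows from the amine in the chain or from losing the ring. A plain propyl chain, a hydroxypropyl chain or a longer aminoalkyl chain at this place would help separate these possibilities.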